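A Methyl Branch on the Chain: What to Expect

A few compounds are considered here, and "the series" means these few. Any claim that something is new, unique, unknown or untested is made for them only; others in the source may bear on it.

Measured so far in an assay on isolated protein for inhibition of Amine oxidase [flavin-containing] A (Homo sapiens), read by fluorescence and Amplex Red, with a stated time of 30 min, tested at 100 uM; a higher number here means a stronger effect of the compound at the concentration tested, a lower number a weaker effect:
Compound 1, `CCCCNc1nnc(SCC(=O)N(Cc2cccc([N+](=O)[O-])c2)c2ccc(F)cc2)s1`, gives 82.3%.
Compound 2, `CCCNc1nnc(SCC(=O)N(Cc2cccc([N+](=O)[O-])c2)c2ccc(F)cc2)s1`, gives 91.1%.

Compound 2 and compound 1 sit within the scatter of each other: the step of a number 8.8 percentage points higher from compound 1 to compound 2 (within the scatter) is the only one measured. Compound 3, `CC(C)CNc1nnc(SCC(=O)N(Cc2cccc([N+](=O)[O-])c2)c2ccc(F)cc2)s1`, is not yet measured; it differs from compound 2 by methyl in place of hydrogen on a saturated chain carbon bound to two saturated chain carbons. That single step, hydrogen in place of methyl on the chain, moved the number by no more than the scatter, so a change in this assay of a number 4.1 percentage points lower from compound 2 to compound 3 (within the scatter) is expected, none beyond the scatter. Compound 3 is estimated at 87%, with a range from 72% to 97%.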

Compound 3, a percentage reported as inhibition, at one concentration (the size of the read-out at that concentration, not a potency): 84.3%
The estimate for compound 3 lay 2.7 percentage points above the measured number; measured number inside the range.
By their numbers in this assay, from the lowest: compounds 1, 3 and 2 (each within the scatter of the next).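

In this assay, a methyl on this saturated chain carbon, which turns propylamino into isobutylamino, gives a number 6.8 percentage points lower from compound 2 to compound 3 (within the scatter) and so leaves the read-out indistinguishable from the unbranched chain. The branched chain also matches the butylamino chain of compound 1, with a number 2 percentage points higher from compound 1 to compound 3 (within the scatter) as the step, so neither one added carbon in a line nor one added as a branch has yet shifted the number beyond the scatter. No evidence bearing on this result is available. Still open, as far as these compounds go, is whether a cyclohexyl ring or a terminal amine on this chain would give a clearly different number.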